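A few compounds are considered here, and "the series" means these few. Any claim that something is new, unique, unknown or untested is made for them only; others in the source may bear on it.

Measured compounds:
- compound 1 (`C=C1[C@H](C)CCC[C@]1(C)CC/C(C)=C/CC1=C(O)C(=O)C=C(N[C@@H](C(=O)O)C(C)C)C1=O`), value (6.2 ug/mL)
- compound 2 (`C=C1[C@H](C)CCC[C@]1(C)CC/C(C)=C/CC1=C(O)C(=O)C=C(NCC(=O)O)C1=O`), value (4 ug/mL)

Both values come from an ADME assay on KB cells (Homo sapiens) for cytotoxicity, with a stated time of 48 h; on this read-out lower numbers stand for stronger inhibition and higher numbers for weaker inhibition. Compound 2 (4 ug/mL) lies within the scatter of compound 1, so the two numbers do not separate.

Compound 3 (`C=C1[C@H](C)CCC[C@]1(C)CC/C(C)=C/CC1=C(O)C(=O)C=C(N[C@H](C(=O)O)C(C)C)C1=O`) has not yet been measured. Its difference from compound 2 (isopropyl in place of hydrogen on a saturated chain carbon bound to an amine nitrogen and a carbonyl carbon) is isopropyl in place of hydrogen on a saturated chain carbon bound to an amine nitrogen and a carbonyl carbon.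

Among the compounds with values here, one measured step bears on this change: a 1.6-fold lower number from compound 1 to compound 2 (0.19 log units; within the scatter) for the same kind of exchange, run the other way. Within the data shown here, that step is small, and it is the only evidence, so a single pair supports no pattern. No step beyond the scatter is therefore expected in this assay, and any drift would most likely be toward a slightly higher number. The expected size is (a 1.5-fold higher number from compound 2 to compound 3 (0.18 log units; within the scatter)), which stays a rough expectation. For compound 3 the estimated value is (6 ug/mL), with an expected range from 3 ug/mL to 12 ug/mL for repeat measurements.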

Compound 3, half-maximal inhibitory concentration: > 10 ug/mL
Compound 3 ended at the assay's limit; the forecaster's own chance of this, stated with the estimate: 5%; middle value at least 1.6-fold (0.22 log units) away from the limit.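

In this assay compound 3 gives > 10 ug/mL, which is a limit of the assay and not a number: the limit of > 10 ug/mL in this assay, at which 1 of the 3 values shown sits.

Even so, isopropyl in place of hydrogen on this saturated chain carbon now produces a step beyond the scatter, an at least 2.5-fold higher number from compound 2 to compound 3 (0.39 log units; beyond the scatter), whereas the same exchange in the other drawn configuration, read in reverse as a 1.6-fold lower number from compound 1 to compound 2 (0.19 log units; within the scatter), stays within it. The exchange at this position therefore reads differently in the two configurations, although the direct comparison, an at least 1.6-fold higher number from compound 1 to compound 3 (0.20 log units; that floor lies within the scatter), has a floor that does not itself separate the pair, whose only difference is this: the fact that compounds 1 and 3 differ only in the configuration as drawn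

Going by these compounds, how far compound 3 lies past the limit remains open, and with it the true size of both steps that end at compound 3. Also open, on these data alone, is whether a methyl or benzyl group on this carbon, or an ester or amide in place of the carboxylic acid, would show a similar difference between configurations, since a single pair of stereoisomers supports no general rule for the series.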